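This account rests on a few compounds, and the source may have more. Where it says the series, first, only, none or still open, it means among the compounds named here.

The measured compounds:
compound 1, `COc1ccc2nc(C)cc(NCc3ccccc3F)c2c1`, 17000 nM
compound 2, `COc1ccc2nc(C)cc(NCc3ccc(F)cc3F)c2c1`, 15000 nM
compound 3, `COc1ccc(CNc2cc(C)nc3ccc(OC)cc23)cc1`, 9700 nM

All three numbers come from a functional assay on MCF-10A cells (Homo sapiens) for antiproliferative activity, with a stated time of 48 h (on this read-out higher numbers stand for an effect only at larger amounts of compound and lower numbers for an effect already at smaller amounts), and the values of compound 1, compound 2 and compound 3 lie within the usual scatter of one another. Compound 2 differs from compound 1 by fluoro in place of hydrogen on an aromatic carbon. That change gave a 1.1-fold lower number from compound 1 to compound 2 (0.05 log units; within the scatter). Compound 4, `COc1ccc2nc(C)cc(NCc3ccc(OC)c(F)c3)c2c1`, has not yet been measured. It differs from compound 3 by fluoro in place of hydrogen on an aromatic carbon. Among the compounds with values here, this is the same kind of change as the one seen between compound 1 and compound 2, but not the same: in compound 2 the new fluoro sits meta to a fluoro group and para to a large group, whereas in compound 4 it sits ortho to a methoxy group and meta to a large group. How the core of compound 3 differs from the core of compound 1 is not broken down here. The expectation for compound 4 rests on compound 1 and compound 2, where the same kind of change gave a 1.1-fold lower number from compound 1 to compound 2 (0.05 log units; within the scatter). The expected step in this assay is a 1.1-fold lower number from compound 3 to compound 4 (0.06 log units; within the scatter), about as small as that earlier one. Compound 4 is therefore estimated at 8500 nM, most likely between 4000 nM and 18000 nM.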

Compound 4, half-maximal effective concentration: 10300 nM
Compound 4: middle estimate off by 1.2-fold (0.08 log units), on the low side; low and high end bracket the measured number.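

In this assay, fluoro in place of hydrogen on an aromatic carbon gave a 1.1-fold higher number from compound 3 to compound 4 (0.03 log units; within the scatter). Set beside the earlier case, the change gives no sign of behaving differently on the two cores: the same change on two cores in this assay, a 1.1-fold lower number (0.05 log units; within the scatter) from compound 1 to compound 2 and a 1.1-fold higher number (0.03 log units; within the scatter) from compound 3 to compound 4, 1.2-fold (0.08 log units) apart, within the scatter of two such steps

Within these two pairs, then, carrying the change across gave the same outcome, namely no step beyond the scatter, but two small steps cannot show that this would hold on other cores or at other places on the ring, and they say nothing about why the number stays put.

Still open, from the compounds shown here alone, is whether another group at the place taken by the fluoro in compound 4, ortho to a methoxy group, such as an amine, a nitrile or a carboxylic acid, would give a step beyond the scatter. Also open, going by these compounds, is whether a longer chain in place of that methoxy group would do so.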